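This account rests on a few compounds, and the source may have more. Where it says the series, first, only, none or still open, it means among the compounds named here.

Measured so far:
compound 1 `CCC(=O)N1CC2CC(C1)N2` — 180 nM
compound 2 `O=C(CC1C=CCC1)N1CC2CC(C1)N2` — 21000 nM

In an assay on CHO cells for agonist activity at Neuronal acetylcholine receptor; alpha3/alpha6/beta2/beta3 (Homo sapiens), read by FLIPR and calcium flux (on this read-out lower numbers stand for an effect already at smaller amounts and higher numbers for an effect only at larger amounts of compound), compound 1 gives 180 nM, the lowest of the two numbers; compound 2 gives 21000 nM. Going by the values given here, the single measured step, a 120-fold higher number from compound 1 to compound 2 (2.07 log units; beyond the scatter), is the only guide here. Compound 3 `O=C([C@H]1C[C@H]1F)N1CC2CC(C1)N2` is not yet measured and differs from compound 1 by 2-fluorocyclopropyl in place of ethyl on a carbonyl carbon. Since the step from compound 1 to compound 2 at the same carbonyl carbon was large and upward, a change at that position is expected to raise the number, though a smaller step is expected for compound 3 with the ring of three carbons. Compound 3 is expected near 900 nM (range 250 nM to 4000 nM), an estimated step of a 5.0-fold higher number from compound 1 to compound 3 (0.70 log units; beyond the scatter).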

Compound 3, half-maximal effective concentration: 62 nM
For compound 3 the middle estimate is 15-fold (1.16 log units) above the measured one, outside the stated range (below it).
By their numbers in this assay, from the lowest: compound 3; then compound 1; then compound 2.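

In this assay the carbonyl position proves open to change in both directions: 2-fluorocyclopropyl in place of ethyl gives a 2.9-fold lower number from compound 1 to compound 3 (0.46 log units; beyond the scatter) and so runs against a 120-fold higher number from compound 1 to compound 2 (2.07 log units; beyond the scatter) in direction. Added heavy atoms at this position therefore do not by themselves raise the number.

Open, as far as these compounds go, is whether plain cyclopropyl, without the fluorine, gives a similar number, and whether the opposite stereoisomer of 2-fluorocyclopropyl does. No measurement at hand bears on why this step goes the way it does.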